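One ring swapped, clearance still unknown

The source may report more compounds than this note shows. Statements on the series, on what has been measured and on what is new or still open speak of the compounds shown alone.

Among the compounds with values here, in an in vitro ADME assay on microsomes from liver (Homo sapiens) for metabolic stability, read by HPLC (a higher number here means faster removal of the compound, a lower number slower removal), compound 2 `NC(=O)[C@@H](CCC(F)(F)F)N(C[C@@H]1COCCO1)S(=O)(=O)c1ccc(Cl)cc1` gives 117 mL/min/kg, the only true number so far. Compound 1 `CC1(C)CO[C@@H]1CN([C@H](CCC(F)(F)F)C(N)=O)S(=O)(=O)c1ccc(Cl)cc1` reads > 293 mL/min/kg, which is a limit of the assay and not a number.

Within the data shown here, the one measured step shows an at least 2.5-fold lower number from compound 1 to compound 2 (0.39 log units; beyond the scatter), with 1,4-dioxan-2-yl in place of 3,3-dimethyloxetan-2-yl on a saturated chain carbon bound to a sulfonamide nitrogen. Compound 3 `NC(=O)[C@@H](CCC(F)(F)F)N(C[C@@H]1CCOC1)S(=O)(=O)c1ccc(Cl)cc1` alters that same place: oxolan-3-yl in place of 1,4-dioxan-2-yl on a saturated chain carbon bound to a sulfonamide nitrogen.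

This single step shows that the group here can shift the number beyond the scatter, but it involves a different pair of groups, so it is only a loose guide. The expected result is a 1.4-fold higher number from compound 2 to compound 3 (0.14 log units; within the scatter), a slight lean upward that probably stays within the scatter. Compound 3 is estimated at 160 mL/min/kg, with an expected range from 80 mL/min/kg to 290 mL/min/kg.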

Compound 3, clearance: 69.8 mL/min/kg
For compound 3 the middle estimate is 2.3-fold (0.36 log units) above the measured one; the whole stated range lies above it.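

In this assay, a 1.7-fold lower number from compound 2 to compound 3 (0.22 log units; within the scatter), so oxolan-3-yl and 1,4-dioxan-2-yl on a saturated chain carbon bound to a sulfonamide nitrogen cannot be told apart here, even though one is a five-membered ring with 1 hetero atom and the other a six-membered ring with 2. Set against 3,3-dimethyloxetan-2-yl, the oxolan-3-yl ring gives an at least 4.1-fold lower number from compound 1 to compound 3 (0.62 log units; beyond the scatter), so a second ring now stands clearly apart from that group. The true size of this step stays unknown because compound 1 gives a limit of the assay and not a number: the limit of > 293 mL/min/kg in this assay, at which 1 of the 3 values shown sits.

From the compounds shown here alone, what a cyclopentyl ring, which has no oxygen, or a pyrrolidin-3-yl ring, which carries an amine, would give at this place remains open. So does the reading of a plain oxetan-2-yl ring without its two methyl groups.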